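The source may hold more compounds than are shown below. What is called first, only, known or untested is meant among the compounds shown, and "the series" means these compounds.

Compound 1 `Cc1ccc(C#Cc2cn(C/C=C\CN3C(=O)c4ccccc4C3=O)c(=O)[nH]c2=O)cc1`: in an ADME assay on WI-38 cells (Homo sapiens) for cytotoxicity, read by MTT assay, with a stated time of 3 days (a higher number here means a weaker inhibitor, a lower number a stronger inhibitor), compound 1 reaches only a limit, > 100000 nM.
Compound 2 `CCCCCCCCC#Cc1cn(C/C=C\CN2C(=O)c3ccccc3C2=O)c(=O)[nH]c1=O`: in this assay compound 2 gives 49000 nM.
Compound 3 `CCCCCC#Cc1cn(C/C=C/CN2C(=O)c3ccccc3C2=O)c(=O)[nH]c1=O`: in this assay compound 3 gives 40000 nM.

Compound 3 holds the lowest of the two numbers, with compound 2 close by and within the scatter; compound 1 sits at a limit (the limit of > 100000 nM in this assay, at which 1 of the 3 values shown sits). Compound 4 `CCCCc1ccc(C#Cc2cn(C/C=C/CN3C(=O)c4ccccc4C3=O)c(=O)[nH]c2=O)cc1` differs from compound 3 in one place: 4-butylphenyl in place of pentyl on a triple-bonded carbon. Within the data shown here, the only measured step that bears on this is the reverse exchange, an at least 2.0-fold lower number from compound 1 to compound 2 (0.30 log units; that floor lies within the scatter), a step whose floor lies within the scatter and whose true size is not known. Going back from a chain to an aryl group, a rise of similar or greater size is expected, a 2.1-fold higher number from compound 3 to compound 4 (0.33 log units; beyond the scatter), possibly up to a limit. Compound 4 is therefore estimated at 85000 nM, in the range 35000 nM to 200000 nM.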

Compound 4, half-maximal inhibitory concentration: 40000 nM
Compound 4: middle estimate off by 2.1-fold (0.33 log units), on the high side; low and high end bracket the measured number.
By their numbers in this assay, from the lowest: compounds 3, 4 and 2 (each within the scatter of the next). At a limit, above all of these: compound 1.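

In this assay, 4-butylphenyl in place of pentyl on a triple-bonded carbon gives no change at the digits printed from compound 3 to compound 4 (within the scatter). At this position, then, an aromatic ring does not by itself go with a higher number, which the earlier step, an at least 2.0-fold lower number from compound 1 to compound 2 (0.30 log units; that floor lies within the scatter), could not show. Compound 1 alone remains at a limit: the limit of > 100000 nM in this assay, at which 1 of the 4 values shown sits.

The compounds shown leave open what an amine or a carboxylic acid at the end of the chain on this carbon would give. They also leave open whether 4-butylphenyl reads the same with the double-bond geometry of compound 1.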